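A few compounds are considered here, and "the series" means these few. Any claim that something is new, unique, unknown or untested is made for them only; others in the source may bear on it.

Compound 1 `COc1ccc2nc(C)cc(OCC(=O)Nc3cc(C)ccc3C)c2c1` — in a toxicity assay on HepG2 cells (Homo sapiens) for inhibition, read by CellTiter-Glo, with a stated time of 48 h (a higher number here means a weaker inhibitor, a lower number a stronger inhibitor), compound 1 gives > 100000 nM, which is a limit of the assay and not a number.
Compound 2 `COc1ccc2nc(C)cc(OCC(=O)Nc3cc(C)nc(C)n3)c2c1` — in this assay compound 2 gives > 100000 nM, again a limit of the assay rather than a number.

Compound 2 therefore stands at the limit in this assay, and both values shown sit at that same limit (the limit of > 100000 nM in this assay, at which 2 of the 2 values shown sit). Among the compounds with values here, the one measured step, a step that the two limits leave unreadable from compound 1 to compound 2, cannot be given a size for this reason: two limits cannot be compared. Compound 3 `COc1ccc2nc(C)cc(OCC(=O)Nc3nc(C)c(C)s3)c2c1` differs from compound 2 by 4,5-dimethyl-1,3-thiazol-2-yl in place of 2,6-dimethylpyrimidin-4-yl on an amide-type nitrogen. Within the data shown here, the only measured step that bears on this change is the one from compound 1 to compound 2, which also exchanged one ring on the amide-type nitrogen and left both ends at the limit. Among the measured compounds shown here, no step of readable size exists, so the expectation for compound 3 in this assay is no change beyond the scatter, and most likely yet another limit. Compound 3 is expected to give about 150000 nM, within the range 50000 nM to 500000 nM. The expected step that the limit leaves unreadable from compound 2 to compound 3 is accordingly estimated to be none of note.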

Compound 3, half-maximal inhibitory concentration: > 100000 nM
Compound 3 ended at the assay's limit (the forecaster's own chance of this, stated with the estimate: 80%); the middle value is on the limit's open side.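

Compound 1, compound 2 and compound 3 all sit at one limit of this assay, so none of the steps among them can be read: the limit of > 100000 nM in this assay, at which 3 of the 3 values shown sit.
The compounds shown leave open whether exchanging the ring on the amide-type nitrogen changes inhibition in this assay at all, and by how much.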